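From methyl to hydrogen on the shared core

The source may report more compounds than this note shows. Statements on the series, on what has been measured and on what is new or still open speak of the compounds shown alone.

Compound 1 `C=Cc1cnccc1-c1cnc(N)nc1C1CC1`: 30000 nM
Compound 2 `CC(C)c1nc(N)ncc1-c1ccncc1`: > 100000 nM (a limit)
Compound 3 `Cc1nc(N)ncc1-c1ccncc1`: > 100000 nM (a limit)

These values come from a functional assay on CUTLL1 cells (Homo sapiens) for inhibition, read by resazurin assay, with a stated time of 48 h, in the absence of a further agent; on this read-out lower numbers stand for an effect already at smaller amounts and higher numbers for an effect only at larger amounts of compound. Compound 1 alone gives a number. Compound 3 stands at the limit of > 100000 nM in this assay, at which 2 of the 3 values shown sit, so its true value is not known.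

Compound 4 `Nc1ncc(-c2ccncc2)cn1` differs from compound 3 in one place, with hydrogen in place of methyl on an aromatic carbon. For the measured compounds named here, the one measured step that bears on this change is a step that the two limits leave unreadable from compound 2 to compound 3, with methyl in place of isopropyl on the same aromatic carbon. That step gives no size to carry forward, and so it offers no sign of a gain or a loss.

No step beyond the usual scatter is therefore expected in this assay, in either direction, and another reading at the limit is the likeliest outcome. The expected size is a number no higher from compound 3 to compound 4 (the limit leaves the size open). Compound 4 is estimated at 100000 nM, with an expected range of 40000 nM to 200000 nM.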

Compound 4, half-maximal effective concentration: > 100000 nM
Compound 4: a limit, no number; the forecaster's own chance of this, stated with the estimate: 85%; the middle value lies on the limit itself.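

Compound 4 gives > 100000 nM in this assay, which is a limit and not a number. The steps among compound 2, compound 3 and compound 4 therefore cannot be read: the limit of > 100000 nM in this assay, at which 3 of the 4 values shown sit.

The compounds shown leave open whether isopropyl, methyl or hydrogen on this aromatic carbon makes any difference in this assay.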